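Heteroaryl swap on the diphenylmethyl sulfoxide series

This account rests on a few compounds, and the source may have more. Where it says the series, first, only, none or still open, it means among the compounds named here.

Going by the values given here, compound 1 `Cc1noc(C[S+]([O-])C(c2ccccc2)c2ccccc2)n1` gives 56700 nM in an assay on HEK293 cells for inhibition of sodium-dependent dopamine transporter (Homo sapiens), read by scintillation counting, with stated times of 5 min and 1 min (on this read-out lower numbers stand for stronger inhibition and higher numbers for weaker inhibition), the highest of the three numbers measured so far. Compound 3 `[O-][S+](Cc1nc(C(F)(F)F)no1)C(c1ccccc1)c1ccccc1` gives 43700 nM; the step of a 1.3-fold lower number from compound 1 to compound 3 (0.11 log units; within the scatter) lies within the scatter. Among the compounds with values here, compound 2 `[O-][S+](Cc1cccs1)C(c1ccc(F)cc1)c1ccc(F)cc1` gives 4000 nM, a lower number than compound 1, but no single-point step links the two. Compound 4 `O=c1[nH]nc(C[S+]([O-])C(c2ccccc2)c2ccccc2)s1` differs from compound 1 by a group of 6 heavy atoms (2 carbon, 2 nitrogen, 1 oxygen, 1 sulfur; one five-membered aromatic ring with 3 hetero atoms) in place of a group of 6 heavy atoms (3 carbon, 2 nitrogen, 1 oxygen; one five-membered aromatic ring with 3 hetero atoms), on a saturated chain carbon bound to a sulfur. Within the data shown here, no measured step touches this part of the molecule except the move from compound 1 to compound 3, which alters a substituent on the same ring and stays within the scatter. With nothing pointing to a sizeable shift, the step of a 1.1-fold lower number from compound 1 to compound 4 (0.05 log units; within the scatter) is expected to remain within the scatter. For compound 4 the estimate is 50000 nM, with a range from 15000 nM to 160000 nM.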

Compound 4, half-maximal inhibitory concentration: 38100 nM
Compound 4: middle estimate off by 1.3-fold (0.12 log units), on the high side, within the range that was stated.
By their numbers in this assay, from the lowest: compound 2; then compounds 4, 3 and 1 (each within the scatter of the next).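

In this assay the whole ring on the saturated chain carbon bound to a sulfur can be exchanged, not just a substituent on it: a 1.5-fold lower number from compound 1 to compound 4 (0.17 log units; within the scatter). This holds even though the entering group adds a hydrogen-bond donor and a double bond outside aromatic rings, whereas the earlier step altered only a substituent. Nothing at hand explains this insensitivity. Open, as far as these compounds go, is whether an amine or a carboxylic acid at this place would leave the number similarly unchanged. Also open, from the compounds shown here alone, is whether ring exchanges here read the same on the core of compound 2.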